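The source may hold more compounds than are shown below. What is called first, only, known or untested is meant among the compounds shown, and "the series" means these compounds.

Compound 1 `O[C@@H]1Cc2cc(Cl)ccc2N[C@H](c2ccccc2)C1`: 191000 nM
Compound 2 `O[C@@H]1Cc2cc(F)ccc2N[C@H](c2ccccc2)C1`: a limit of the assay, > 300000 nM
Compound 3 `O[C@@H]1Cc2ccccc2N[C@H](c2ccc(Cl)cc2)C1`: a limit of the assay, > 300000 nM

In an ADME assay on Vero cells (Chlorocebus sabaeus) for cytotoxicity, read by MTT assay, with a stated time of 72 h (on this read-out lower numbers stand for higher toxicity in this test and higher numbers for lower toxicity in this test), compound 1 gives 191000 nM. Compound 2 gives only a limit of the assay, > 300000 nM. The change from compound 1 to compound 2 is fluoro in place of chloro on an aromatic carbon and yields an at least 1.5-fold higher number from compound 1 to compound 2 (0.19 log units; that floor lies within the scatter). Compound 3 likewise gives only a limit of the assay, > 300000 nM. Compound 1 and compound 3 have the same atoms joined differently; the difference between the two cores is not broken down here. Compound 4 `O[C@@H]1Cc2ccccc2N[C@H](c2ccc(F)cc2)C1` awaits measurement in this assay and differs from compound 3 by fluoro in place of chloro on an aromatic carbon. The place is not the same as in the first pair: there the ring was part of a fused or bridged system of two rings, meta to a fused ring and para to a fused ring; here it is para to a large group, so this is the same kind of change. For compound 4 a step that the limit leaves unreadable from compound 3 to compound 4 is expected, resting on compound 3 with > 300000 nM and on (the limit of > 300000 nM in this assay, at which 2 of the 3 values shown sit). Compound 4 is thus estimated at 400000 nM, most likely again reported as a limit.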

Compound 4, half-maximal cytotoxic concentration: > 300000 nM
Compound 4: no number, only a limit (the forecaster's own chance of this, stated with the estimate: 80%); the middle value does not contradict the limit.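

Compound 3 and compound 4 both give only a limit in this assay, so the step between them cannot be read: the limit of > 300000 nM in this assay, at which 3 of the 4 values shown sit.

The compounds shown leave open whether fluoro in place of chloro at this place changes the half-maximal cytotoxic concentration at all.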